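A few compounds are considered here, and "the series" means these few. Any claim that something is new, unique, unknown or untested is made for them only; others in the source may bear on it.

For the measured compounds named here, in a functional assay on the whole organism with Mus musculus as the target (a lower number here means that less compound is needed, a higher number that more compound is needed for the effect), two compounds sharing one core have numbers so far. Compound 1 `CNC(=O)Cn1c(-c2ccc(Cl)cc2)nc2cccnc21` gives 12.5 mg/kg, and compound 2 `CN(C)CCNC(=O)Cn1c(-c2ccc(Cl)cc2)nc2cccnc21` gives 62 mg/kg, the higher of the two. Going by the values given here, the one measured step, a 5.0-fold higher number from compound 1 to compound 2 (0.70 log units; beyond the scatter), puts (dimethylamino)methyl in place of hydrogen on a saturated chain carbon bound to an amide-type nitrogen.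

Compound 3 `CN(C)C(=O)CCn1c(-c2ccc(Cl)cc2)nc2cccnc21` has no number yet. It differs from compound 2 by (dimethylcarbamoyl)methyl in place of (2-(dimethylamino)ethyl)carbamoyl on a saturated chain carbon bound to an aromatic nitrogen: (dimethylcarbamoyl)methyl stands in place of (2-(dimethylamino)ethyl)carbamoyl on a saturated chain carbon bound to an aromatic nitrogen.

Among the compounds with values here, only the step from compound 1 bears on this change, and only in part. Within the data shown here, compound 3 lacks the chain that step added, but it is no simple return to compound 1, and no measured step speaks to the loss of the amide hydrogen. Part of the modest rise in a 5.0-fold higher number from compound 1 to compound 2 (0.70 log units; beyond the scatter) is therefore expected to be undone, with the number falling towards that of compound 1. The expected change is a 2.8-fold lower number from compound 2 to compound 3 (0.45 log units; beyond the scatter). For compound 3 the estimate is 22 mg/kg, with an expected range from 8 mg/kg to 60 mg/kg.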

Compound 3, dose for half-maximal effect: 29.4 mg/kg
Beside the measured number, compound 3's estimate is 1.3-fold (0.13 log units) below it; measured number inside the range.
By their numbers in this assay, from the lowest: compound 1; then compound 3; then compound 2.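

In this assay, (dimethylcarbamoyl)methyl in place of (2-(dimethylamino)ethyl)carbamoyl on a saturated chain carbon bound to an aromatic nitrogen gives a 2.1-fold lower number from compound 2 to compound 3 (0.32 log units; beyond the scatter), so the number can be brought down at this position without returning to the group of compound 1. The same group still gives a 2.4-fold higher number from compound 1 to compound 3 (0.37 log units; beyond the scatter), which shows that a group without the dimethylamino end can also raise the number over that of compound 1, so the rise seen earlier is not tied to that end alone. No measurement at hand explains either step, and these numbers alone cannot give a cause.

The step from compound 1 to compound 3 replaces methylcarbamoyl as a whole, so the compounds shown do not separate the effect of the loss of the amide hydrogen from that of the rest of the change. As far as these compounds go, it also remains open how this position would respond to a carboxylic acid, a primary amide or a morpholine amide, or to a longer chain ending in an amide.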